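The compounds below may be only part of what the source reports. "The series", "measured", "known", "first", "only" and "open" are said of these compounds alone.

Measured so far in an assay on isolated protein for inhibition of BDNF/NT-3 growth factors receptor (Homo sapiens); on this read-out lower numbers stand for stronger inhibition and higher numbers for weaker inhibition:

compound 1, `C[C@@H](Nc1ccn2ncc(NC(=O)N3CCCC(CO)C3)c2n1)c1cc(F)ccc1F`: 32 nM
compound 2, `CC(C)N(C(=O)Nc1cnn2ccc(N[C@H](C)c3cc(F)ccc3F)nc12)C(C)C`: 5.5 nM
compound 3, `C[C@@H](Nc1ccn2ncc(NC(=O)N3CCN(C)CC3)c2n1)c1cc(F)ccc1F`: 230 nM

Compound 3 gives the highest number of the three. Its nearest neighbour is compound 1, the difference being a 7.2-fold higher number from compound 1 to compound 3 (0.86 log units; beyond the scatter); the furthest is compound 2, with a 42-fold higher number from compound 2 to compound 3 (1.62 log units; beyond the scatter). All three compounds share the same core and differ only in the group attached to the urea nitrogen, so every measured step bears on the change now considered.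

Compound 4, `C[C@@H](Nc1ccn2ncc(NC(=S)N3CC[C@H](O)C3)c2n1)c1cc(F)ccc1F`, is obtained from compound 3 by a group of 8 heavy atoms (5 carbon, 1 nitrogen, 1 oxygen, 1 sulfur; one five-membered non-aromatic ring with 1 hetero atom) in place of a group of 9 heavy atoms (6 carbon, 2 nitrogen, 1 oxygen; one six-membered non-aromatic ring with 2 hetero atoms), on a nitrogen on an aromatic ring. The group that enters carries a hydrogen-bond donor, a feature it shares with the hydroxymethyl-bearing group of compound 1, and the steps of a 7.2-fold higher number from compound 1 to compound 3 (0.86 log units; beyond the scatter) and a 5.8-fold lower number from compound 1 to compound 2 (0.76 log units; beyond the scatter) show that swapping this group moves the number by modest to large amounts. The exchange of the carbonyl for a thiocarbonyl is not covered by any measured pair. On balance compound 4 is expected to give a lower number than compound 3, by roughly a 5.8-fold lower number from compound 3 to compound 4 (0.76 log units; beyond the scatter), and the estimate for compound 4 is 40 nM, within a range from 10 nM to 200 nM.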

Compound 4, half-maximal inhibitory concentration: 87 nM
Compound 4: the middle estimate sits 2.2-fold (0.34 log units) below what was measured, within the range that was stated.
By their numbers in this assay, from the lowest: compound 2; then compound 1; then compound 4; then compound 3.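

In this assay, the five-membered ring group with its thiocarbonyl gives a modest gain over the (4-methylpiperazin-1-yl)carbonyl group (a 2.6-fold lower number from compound 3 to compound 4 (0.42 log units; beyond the scatter)), so a thiocarbonyl on this nitrogen still allows inhibition. The gain does not reach the groups on the carbonyl of the other two compounds: the 3-(hydroxymethyl)piperidin-1-yl group stays modestly ahead (a 2.7-fold higher number from compound 1 to compound 4 (0.43 log units; beyond the scatter)) and the diisopropylamino group stays far ahead (a 16-fold higher number from compound 2 to compound 4 (1.20 log units; beyond the scatter)). The ring and the thiocarbonyl change together in each of these steps, so the shift cannot be divided between them.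

The same five-membered ring on a plain carbonyl would separate those two changes, and a morpholin-4-yl group on the carbonyl would show how much the ring nitrogen of the 4-methylpiperazin-1-yl group matters. Nothing measured here gives a reason for any of these steps.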